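This account rests on a few compounds, and the source may have more. Where it says the series, first, only, none or still open, it means among the compounds named here.

Compound 1 `CCCc1nc(-c2ccccc2)c(CNCCCN2CCN(c3ccccc3Cl)CC2)o1` gives 2800 nM in an assay on HEK293 cells for inhibition of Voltage-dependent T-type calcium channel subunit alpha-1G (Homo sapiens), read by patch clamp; on this read-out lower numbers stand for stronger inhibition and higher numbers for weaker inhibition.
Compound 2 `CCCc1nc(-c2ccccc2)c(CNCCCN2CCN(c3cccc(Cl)c3)CC2)o1` gives 1750 nM in this assay.
Compound 3 `CCCc1nc(-c2ccccc2)c(CNCCCN2CCN(c3ccc(C)cc3)CC2)o1` gives 130000 nM in this assay.

Compound 3 carries the highest of the three numbers: against compound 1 there is a 46-fold higher number from compound 1 to compound 3 (1.67 log units; beyond the scatter), and against compound 2 there is a 74-fold higher number from compound 2 to compound 3 (1.87 log units; beyond the scatter). Compounds 1 and 2 lie close together, since a 1.6-fold lower number from compound 1 to compound 2 (0.20 log units; within the scatter).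

Compound 4 `CCCc1nc(-c2ccccc2)c(CNCCCN2CCN(c3ccccc3C)CC2)o1` has the same atoms as compound 3, joined differently: 2-methylphenyl in place of 4-methylphenyl on an amine nitrogen in a ring. Two kinds of measured step bear on it. The step from compound 1 to compound 2 moves a chlorine substituent between two ring positions and stays within the scatter. The steps to compound 3 are large, but each combines a swap of chlorine for methyl with a change of ring position. These data do not separate the two changes from each other. Because compound 1, with its 2-chlorophenyl, shows 2800 nM, a move of the methyl group to the same ring position is expected to bring compound 4 down from compound 3, with an 8.7-fold lower number from compound 3 to compound 4 (0.94 log units; beyond the scatter) as the estimated step, though its size is uncertain. For compound 4 the expected value in this assay is 15000 nM, within a range from 3000 nM to 60000 nM.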

Compound 4, half-maximal inhibitory concentration: 8750 nM
Compound 4: the middle estimate sits 1.7-fold (0.23 log units) above what was measured; measured number inside the range.
By their numbers in this assay, from the lowest: compounds 2 and 1 (each within the scatter of the next); then compound 4; then compound 3.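

Compounds 3 and 4 have the same atoms, so they isolate the effect of ring position: in this assay, moving the methyl group gives a 15-fold lower number from compound 3 to compound 4 (1.17 log units; beyond the scatter), a large change with no change in atoms. This shows that the earlier large steps to compound 3 cannot be credited to the swap of chlorine for methyl alone. With the position held fixed, methyl in place of chloro gives a 3.1-fold higher number from compound 1 to compound 4 (0.49 log units; beyond the scatter), a modest step beyond the scatter, while the step that changes both group and position, 2-methylphenyl in place of 3-chlorophenyl, gives a 5.0-fold higher number from compound 2 to compound 4 (0.70 log units; beyond the scatter), which is also modest.

The compounds shown leave open whether a 4-chlorophenyl would give a number as high as that of compound 3, which would tie the loss to that ring position rather than to methyl there, and where a 3-methylphenyl would fall. No supporting measurement is available to explain why moving the methyl group changes the number so strongly.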